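This account rests on a few compounds, and the source may have more. Where it says the series, first, only, none or still open, it means among the compounds named here.

Measured compounds in an ADME assay on Vero cells (Chlorocebus sabaeus) for cytotoxicity, read by MTT assay, with a stated time of 96 h; a higher number here means that more compound is tolerated, a lower number that less compound is tolerated:
compound 1 `COc1ccc(CNc2ccc(-c3cnco3)c(OC)c2)cc1` gives 23900 nM
compound 2 `COc1cc(/N=C/c2ccc(F)cc2)ccc1-c1cnco1` gives 325000 nM
compound 3 `COc1cc(NCc2cncs2)ccc1-c1cnco1` gives 232000 nM

Compound 2 has the highest of the three numbers in this assay. Compound 3 sits nearest, and the gap between compound 2 and compound 3 lies within the scatter, so the two cannot be ordered. Compound 1 lies furthest away, beyond the scatter, so compound 2 is tolerated at clearly higher concentration than compound 1. Going by the values given here, no pair of measured compounds differs in only one place, so no single-point step can be read from the series.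

Compound 4 `COc1cc(/N=C/c2cccs2)ccc1-c1cnco1` is not yet measured in this assay. Compared with compound 2 it carries thiophen-2-yl in place of 4-fluorophenyl on a carbon with a double bond to nitrogen. Among the compounds with values here, the series contains no measured pair that isolates a change of this kind, so the expectation rests on the spread of the three numbers alone, with compound 3 at 232000 nM as the closest reference to compound 2 at 325000 nM.

In this assay the step from compound 2 to compound 4 is expected to be small, most likely not beyond the scatter, and if anything slightly downward, a 1.3-fold lower number from compound 2 to compound 4 (0.11 log units; within the scatter). Compound 4 is therefore estimated at 250000 nM, with a range from 100000 nM to 600000 nM.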

Compound 4, half-maximal cytotoxic concentration: 406000 nM
Beside the measured number, compound 4's estimate is 1.6-fold (0.21 log units) below it; the measured number falls inside the stated range.
By their numbers in this assay, from the lowest: compound 1; then compounds 3, 2 and 4 (each within the scatter of the next).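

In this assay, going by these compounds alone, the single exchange on a carbon with a double bond to nitrogen gives a 1.2-fold higher number from compound 2 to compound 4 (0.10 log units; within the scatter), the first step that isolates one place, and it lies within the scatter. At this place, a five-membered aromatic ring with 1 hetero atom, thiophen-2-yl, and a six-membered aromatic ring of carbon only, 4-fluorophenyl, therefore cannot be ordered by tolerated concentration, even though the two groups differ in ring size, hetero atom and hydrogen-bond acceptor count. No measured property bears on this result, so the reading stops at the numbers themselves.

Within the data shown here, this single pair covers only two aromatic rings, so it remains open whether the same place would read alike with a saturated ring such as cyclohexyl, a basic group such as a dimethylamino-substituted phenyl, or a carboxylic acid on the ring. The gap between compound 1 and the other compounds also remains unassigned, since compound 1 differs from each of them in more than one place and no single change can be held to account for it.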